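Swapping the sulfonyl substituent of compound 3 for a thiazole

The source may report more compounds than this note shows. Statements on the series, on what has been measured and on what is new or still open speak of the compounds shown alone.

Compound 1, `CC(O)(C(=O)Nc1ccc(S(=O)(=O)c2cccc(F)c2)cc1)C(F)(F)F`, in a functional assay (Cavia porcellus) with sulfonylurea receptors; K-ATP channels (Homo sapiens) as the target (on this read-out higher numbers stand for weaker inhibition and lower numbers for stronger inhibition), gives 3400 nM.
Compound 2, `CC(O)(C(=O)Nc1ccc(S(=O)(=O)c2ccccc2O)cc1)C(F)(F)F`, in this assay gives 3090 nM.
Compound 3, `CN(c1ccccc1)S(=O)(=O)c1ccc(NC(=O)C(C)(O)C(F)(F)F)cc1`, in this assay gives 2000 nM.

All three compounds share the same core and differ only in the group attached to the sulfonyl sulfur. Compound 3 has the lowest of the three numbers, but its separation from compound 2 and from compound 1 is within the usual scatter, so the three cannot be told apart on this read-out.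

Compound 4, `CC(O)(C(=O)Nc1ccc(S(=O)(=O)c2cncs2)cc1)C(F)(F)F`, is not yet measured. Its change from compound 3 is 1,3-thiazol-5-yl in place of methyl(phenyl)amino on a sulfonyl sulfur. Going by the values given here, the steps that bear on this change are the earlier swaps at the same place: a 1.1-fold lower number from compound 1 to compound 2 (0.04 log units; within the scatter), a 1.7-fold lower number from compound 1 to compound 3 (0.23 log units; within the scatter) and a 1.5-fold lower number from compound 2 to compound 3 (0.19 log units; within the scatter). Each of these exchanged one group on the sulfonyl sulfur for another and none moved the number beyond the scatter. Among the compounds with values here, no measured step covers a five-membered aromatic ring at this position, so the expectation rests only on that quiet record.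

Compound 4 is therefore expected to give 3000 nM, with a range from 1000 nM to 9000 nM. That corresponds to an expected step of a 1.5-fold higher number from compound 3 to compound 4 (0.18 log units; within the scatter), which lies within the scatter.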

Compound 4, half-maximal inhibitory concentration: 7700 nM
Compound 4: the middle estimate sits 2.6-fold (0.41 log units) below what was measured; the measured number falls inside the stated range.
By their numbers in this assay, from the lowest: compounds 3, 2 and 1 (each within the scatter of the next); then compound 4.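

In this assay the earlier swaps on the sulfonyl sulfur gave no step beyond the scatter, whereas the 1,3-thiazol-5-yl group gives modest steps beyond it in all three comparisons: a 3.9-fold higher number from compound 3 to compound 4 (0.59 log units; beyond the scatter) and a 2.5-fold higher number from compound 2 to compound 4 (0.40 log units; beyond the scatter) and also a 2.3-fold higher number from compound 1 to compound 4 (0.36 log units; beyond the scatter) in the same direction. This shows that the group at this position can change the number after all, and that this change makes compound 4 the weakest inhibitor of the four. Nothing measured here explains why this group stands apart from the other three.

The compounds shown include only one five-membered aromatic ring, so it remains open whether a thiophene, a furan or an imidazole on the sulfonyl sulfur would give a number like that of compound 4 or one closer to those of compounds 1, 2 and 3. They also leave open what a non-aromatic group would do there, such as a piperidine, a short alkyl chain or a chain ending in a carboxylic acid.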